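Lengthening a Linear Polyamine One Methylene at a Time

A few compounds are considered here, and "the series" means these few. Any claim that something is new, unique, unknown or untested is made for them only; others in the source may bear on it.

Four linear polyamines are compared here. Compound 1 has the structure `CCNCCCNCCCN`, compound 2 the structure `CCNCCCCNCCCN`, compound 3 the structure `CCNCCCCNCCCCNCC`, and compound 4, not yet measured, the structure `CCNCCCCCNCCCCNCC`.

In a functional assay on L1210 cells (Mus musculus) for inhibition, with a stated time of 48 h (a lower number here means a stronger inhibitor, a higher number a weaker inhibitor), compound 1 gives only a limit, > 100000 nM. Compound 2 likewise gives only a limit in this assay, > 100000 nM. Among the measured compounds shown here, compound 3 is the one compound with a number in this assay, 22000 nM.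

Compound 2 differs from compound 1 by (ethylamino)methyl in place of ethylamino on a saturated chain carbon, three bonds along the chain from an amine nitrogen. Because of the limit of > 100000 nM in this assay, at which 2 of the 3 values shown sit, that step reads as a step that the two limits leave unreadable from compound 1 to compound 2. From compound 2 to compound 3 the change is (ethylamino)methyl in place of amino on a saturated chain carbon, three bonds along the chain from an amine nitrogen, and this assay shows an at least 4.5-fold lower number from compound 2 to compound 3 (0.65 log units; beyond the scatter). The difference between the cores of compound 1 and compound 3 is not broken down here.

Compound 4 differs from compound 3 by (ethylamino)methyl in place of ethylamino on a saturated chain carbon, four bonds along the chain from an amine nitrogen. This is the same kind of change as that from compound 1 to compound 2, but here it sits four bonds along the chain from an amine nitrogen rather than three. The earlier instance of the change is unreadable, so the expectation for compound 4 rests on compound 3 and its value 22000 nM, with a modest gain expected, a 2.2-fold lower number from compound 3 to compound 4 (0.34 log units; beyond the scatter). Compound 4 is therefore estimated at 10000 nM, between 3000 nM and 40000 nM.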

Compound 4, half-maximal inhibitory concentration: 4500 nM
Compound 4: the middle estimate sits 2.2-fold (0.35 log units) above what was measured; measured number inside the range.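

In this assay, among the compounds shown here, the swap of ethylamino for (ethylamino)methyl can be read on only one core, that of compound 3, where it gives a 4.9-fold lower number from compound 3 to compound 4 (0.69 log units; beyond the scatter). The same kind of change on the core of compound 1, three bonds along the chain from an amine nitrogen rather than four, cannot be read because both compounds of that pair sit at a limit: the limit of > 100000 nM in this assay, at which 2 of the 4 values shown sit. The series therefore shows one clear gain for this change and a still larger distance to the weaker end of the set, an at least 22-fold lower number from compound 2 to compound 4 (1.34 log units; beyond the scatter), a step that replaces amino with 2-(ethylamino)ethyl, but it does not show that the change carries from one core to another or that its size holds across cores.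

The compounds shown leave open whether the trend goes on with a longer chain, such as 2-(ethylamino)ethyl in place of the (ethylamino)methyl of compound 4, or whether it stops there. For the compounds shown here, they also leave open how much the ethyl groups at the chain ends contribute, since no compound here carries a methyl or propyl group at those ends.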